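Removing the chloro group: what happens to affinity

The source may report more compounds than this note shows. Statements on the series, on what has been measured and on what is new or still open speak of the compounds shown alone.

Measured compounds:
- compound 1, `Cc1ccc2c(O)c(C(=O)NCCC(C)C)cnc2n1`: > 10000 nM
- compound 2, `CC(=O)Nc1ccc2c(O)c(C(=O)NCc3ccccc3)cnc2n1`: > 10000 nM
- compound 3, `O=C(NCc1ccccc1)c1cnc2nc(Cl)ccc2c1O`: 586 nM

In an assay for binding affinity to adenosine receptor A1 (Bos taurus) (a higher number here means a weaker inhibitor, a lower number a stronger inhibitor), compound 1 gives only a limit, > 10000 nM. In this assay compound 2 likewise gives only a limit, > 10000 nM. In this assay, among the measured compounds shown here, compound 3 gives 586 nM, the only real number among the three; the other two sit at the limit of > 10000 nM in this assay, at which 2 of the 3 values shown sit.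

Compound 4, `O=C(NCc1ccccc1)c1cnc2ncccc2c1O`, has not yet been measured. It differs from compound 3 by hydrogen in place of chloro on an aromatic carbon.

For the measured compounds named here, the one step with numbers behind it is an at least 17-fold lower number from compound 2 to compound 3 (1.23 log units; beyond the scatter), which shows that the chloro group is tied to the only measurable affinity seen here. Going by the values given here, no measured step swaps chloro for hydrogen directly, so the size of the move can only be guessed from that single comparison. Taking the chloro group away is therefore expected to weaken binding, and the step of a 4.3-fold higher number from compound 3 to compound 4 (0.63 log units; beyond the scatter) is estimated to be moderate rather than dramatic. For compound 4 in this assay the expected value is 2500 nM, with a range from 600 nM to 10000 nM.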

Compound 4, inhibition constant: 2750 nM
Compound 4: the middle estimate sits 1.1-fold (0.04 log units) below what was measured; the range from low to high includes it.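

In this assay, replacing the chloro group next to the ring nitrogen with hydrogen gives a 4.7-fold higher number from compound 3 to compound 4 (0.67 log units; beyond the scatter), so chloro adds to affinity here but is not needed for measurable binding. Hydrogen at the same place still does better than acetamido, with an at least 3.6-fold lower number from compound 2 to compound 4 (0.56 log units; beyond the scatter), so the earlier gap between acetamido and chloro was not purely a gain from chloro: acetamido itself costs affinity compared with having no group there. The size of that cost is only a minimum, as compound 2 gives a limit and not a real number: the limit of > 10000 nM in this assay, at which 2 of the 4 values shown sit.

Still open, as far as these compounds go, is whether another small group at this place, such as bromo, methoxy or an amine, would match or improve on chloro. From the compounds shown here alone, it is also open whether the same order of chloro, hydrogen and acetamido would hold with a longer chain in place of the benzyl group on the amide.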